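Swapping a methoxy for chloro on a shared core

The source may hold more compounds than are shown below. What is called first, only, known or untested is meant among the compounds shown, and "the series" means these compounds.

Two compounds from this study share a core and differ in the groups attached to it. Compound 1 `COc1ccc2c(c1)/C(=C1/Nc3ccccc3/C1=N\O)C(=O)N2Cc1ccc(/C=C/C(=O)NO)cc1` carries a methoxy on one aromatic ring. Compound 2 `O=C(NO)c1ccc(CN2C(=O)/C(=C3\Nc4ccccc4\C3=N/O)c3cc(F)ccc32)cc1` carries a fluoro there instead, and its hydroxamic acid end is built differently. In a functional assay on SW-620 cells (Homo sapiens) for cytotoxicity, read by colorimetric assay (on this read-out lower numbers stand for stronger inhibition and higher numbers for weaker inhibition), compound 1 gives 40 nM, while compound 2 gives 20 nM. Of these two numbers, that of compound 1 is the higher, but the gap to compound 2 lies within the usual scatter of repeated measurements, so the two cannot be told apart with confidence.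

Compound 3 `O=C(/C=C/c1ccc(CN2C(=O)/C(=C3\Nc4ccccc4\C3=N/O)c3cc(Cl)ccc32)cc1)NO` is the next compound to be measured. It differs from compound 1 in one place: chloro in place of methoxy on an aromatic carbon. Among the compounds with values here, with no step between measured compounds available for this change, there is nothing to lean on beyond the fact that compound 1 and compound 2 sit close together in this assay. The estimated step from compound 1 to compound 3 is therefore small, a 1.3-fold lower number from compound 1 to compound 3 (0.12 log units; within the scatter), in no clear direction beyond the scatter. For compound 3 the expected value in this assay is 30 nM, with a range from 10 nM to 100 nM.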

Compound 3, half-maximal inhibitory concentration: 80 nM
Beside the measured number, compound 3's estimate is 2.7-fold (0.43 log units) below it; the measured number falls inside the stated range.
By their numbers in this assay, from the lowest: compounds 2, 1 and 3 (each within the scatter of the next, the first and the last beyond it).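

In this assay, within the data shown here, chloro in place of methoxy on this aromatic carbon gives a 2.0-fold higher number from compound 1 to compound 3 (0.30 log units; within the scatter) and provides the first direct reading of this change, with the rest of the molecule unchanged. Methoxy has 2 heavy atoms and 1 hydrogen-bond acceptor, while chloro has 1 heavy atom and 0 hydrogen-bond acceptors, yet the step stays within the scatter, so this assay cannot tell these two groups apart at this position. No supporting measurement is available to explain this result.

Fluoro in compound 2 gives no clean reading at this position, since that compound also has a differently built hydroxamic acid end, so only this one pair speaks to the position directly. The compounds shown leave open whether an amine, a carboxylic acid or a longer chain such as butoxy on the same aromatic carbon would give a step beyond the scatter, and whether this position matters much for the number in this cell assay.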